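A few compounds are considered here, and "the series" means these few. Any claim that something is new, unique, unknown or untested is made for them only; others in the source may bear on it.

compound 1 `COc1ccc(/C=C/C(=O)c2ccc(N)c(-c3ccc(F)cc3)c2)cc1O` with "not determined" (no result reported)
compound 2 `COc1ccc(/C=C/C(=O)c2ccc(N)c(-c3ccc(F)cc3)c2)cc1` with 7230 nM
compound 3 `COc1cc(/C=C/C(=O)c2ccc(N)c(-c3ccc(F)cc3)c2)cc(OC)c1OC` with 6120 nM

These three compounds share a core and were tested in a functional assay on SW480 cells (Homo sapiens) for cytotoxicity, read by sulforhodamine B assay, with a stated time of 48 h; on this read-out lower numbers stand for stronger inhibition and higher numbers for weaker inhibition. Among the compounds with values here, compound 1 has no usable number, so only two values can be compared. In this assay compound 3 gives 6120 nM, the lower of the two numbers, but compound 2 at 7230 nM lies within the usual scatter of it. The two therefore cannot be ranked.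

The next compound to be tested is compound 4 `COc1ccc(/C=C/C(=O)c2ccc(N)c(-c3ccc(F)cc3)c2)cc1OC`. Compared with compound 3, it has hydrogen in place of methoxy on an aromatic carbon. Within the data shown here, no measured pair shows this single change on its own, so the expectation rests on the closeness of compound 2 and compound 3. No step beyond the scatter is expected, in either direction, and the estimated change is a 1.1-fold higher number from compound 3 to compound 4 (0.03 log units; within the scatter). For compound 4 the expected value is 6500 nM, within an estimated range from 3000 nM to 14000 nM.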

Compound 4, half-maximal inhibitory concentration: 6640 nM
Compound 4: the middle estimate sits 1.0-fold (0.01 log units) below what was measured; low and high end bracket the measured number.
By their numbers in this assay, from the lowest: compounds 3, 4 and 2 (each within the scatter of the next).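

In this assay, within the data shown here, hydrogen in place of methoxy gives a 1.1-fold higher number from compound 3 to compound 4 (0.04 log units; within the scatter) and methoxy in place of hydrogen gives a 1.1-fold lower number from compound 2 to compound 4 (0.04 log units; within the scatter) on the same ring, and these are the first single-place steps that can be read. Both steps lie within the scatter, so at these places on the ring this read-out cannot tell a methoxy group from a hydrogen atom. Nothing measured here explains why these numbers lie so close together.

Going by these compounds, whether a very different group at these places, such as a chlorine atom or a carboxylic acid, would give a clear step remains open. The hydroxyl group is also unresolved, as compound 1, which carries one, gives "not determined" (no result reported) in this assay and so offers no number for comparison.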